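The source may report more compounds than this note shows. Statements on the series, on what has been measured and on what is new or still open speak of the compounds shown alone.

Measured in a functional assay on HT-29 cells (Homo sapiens) for cytotoxicity, read by sulforhodamine B assay; on this read-out lower numbers stand for higher toxicity in this test and higher numbers for lower toxicity in this test:
- Compound 1 `CC1=CC[C@@H]([C@@](C)(O)CCCC(C)(C)NC(=S)N/N=C\c2ccc(C)cc2)CC1` gives > 100000 nM, a limit of the assay
- Compound 2 `CC1=CC[C@@H]([C@@](C)(O)CCCC(C)(C)NC(=S)N/N=C\c2ccc(O)cc2)CC1` gives 58500 nM
- Compound 3 `CC1=CC[C@@H]([C@@](C)(O)CCCC(C)(C)NC(=S)N/N=C\c2ccccc2[N+](=O)[O-])CC1` gives 44400 nM

Compound 3 stands level with compound 2, with a 1.3-fold lower number from compound 2 to compound 3 (0.12 log units; within the scatter). Against the limit of compound 1 there is an at least 2.2-fold lower number from compound 1 to compound 3 (0.35 log units; beyond the scatter).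

Compound 4 `CC1=CC[C@@H]([C@@](C)(O)CCCC(C)(C)NC(=S)N/N=C\c2cccc([N+](=O)[O-])c2)CC1` has 3-nitrophenyl in place of 2-nitrophenyl on a carbon with a double bond to nitrogen. Within the data shown here, no measured pair tests this exchange directly. Among the measured compounds shown here, the two steps reaching compound 3 both start from a different group at that carbon, and the one between measured numbers is small: a 1.3-fold lower number from compound 2 to compound 3 (0.12 log units; within the scatter). No step beyond the scatter is therefore expected in this assay, the expected change being a 1.1-fold higher number from compound 3 to compound 4 (0.05 log units; within the scatter). For compound 4 the estimated value is 50000 nM, with an expected range of 25000 nM to 100000 nM.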

Compound 4, concentration lethal to 50% of the cells: > 100000 nM
Compound 4 ended at the assay's limit; the forecaster's own chance of this, stated with the estimate: 15%; middle value at least 2.0-fold (0.30 log units) away from the limit.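

In this assay, the same atoms joined differently already separate the pair at this carbon: an at least 2.2-fold higher number from compound 3 to compound 4 (0.35 log units; beyond the scatter), so the place of the nitro group on the phenyl ring counts, not only its presence. The floor of an at least 1.7-fold higher number from compound 2 to compound 4 (0.23 log units; that floor lies within the scatter) does not separate compound 4 from compound 2. The step between compound 1 and compound 4 cannot be read, both values being limits: the limit of > 100000 nM in this assay, at which 2 of the 4 values shown sit.

Going by these compounds, how far compound 4 lies beyond that limit stays open. Also open, on these data alone, is whether 4-nitrophenyl or 2-aminophenyl on this carbon would follow compound 3 or compound 4.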